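A few compounds are considered here, and "the series" means these few. Any claim that something is new, unique, unknown or untested is made for them only; others in the source may bear on it.

Compound 1 `N#Cc1cccc(N2CCN(CCCCNC(=O)c3ccc(-c4ccsc4)cc3)CC2)c1` gives in an ADME assay on microsomes from liver (Rattus norvegicus) for metabolic stability, read by LC-MS, using NADPH (a higher number here means that the compound lasts longer, a lower number that the compound disappears faster), a value of > 1 h, which is a limit of the assay rather than a number.
Compound 2 `N#Cc1ccc(N2CCN(CCCCNC(=O)c3ccc(-c4ccsc4)cc3)CC2)cc1` gives in this assay 0.22 h.

Compound 2 thus holds the only plain number shown; compound 1 reaches only a limit (the limit of > 1 h in this assay, at which 1 of the 2 values shown sits). Compound 3 `O=C(NCCCCN1CCN(c2ccccc2C(F)(F)F)CC1)c1ccc(-c2ccsc2)cc1` carries the change (2-(trifluoromethyl)phenyl in place of 4-cyanophenyl on an amine nitrogen in a ring). Among the compounds with values here, only one measured step bears on it: an at least 4.5-fold lower number from compound 1 to compound 2 (0.65 log units; beyond the scatter), a swap on the same ring nitrogen whose size lay beyond the scatter. A step of similar size is therefore plausible, most likely back toward longer half-life. For compound 3 the expected value is 0.45 h, within 0.12 h to 1.5 h, an estimated 2.0-fold higher number from compound 2 to compound 3 (0.31 log units; beyond the scatter).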

Compound 3, half-life: 0.0667 h
For compound 3 the middle estimate is 6.7-fold (0.83 log units) above the measured one, and the stated range ends above it.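

Changing only the group on this ring nitrogen again moves the half-life in this assay: replacing 4-cyanophenyl with 2-(trifluoromethyl)phenyl gives a 3.3-fold lower number from compound 2 to compound 3 (0.52 log units; beyond the scatter). Measured against the 3-cyanophenyl group, the same replacement gives an at least 14-fold lower number from compound 1 to compound 3 (1.17 log units; beyond the scatter), so this one position spans a wide range across the three compounds. Compound 1 stands at a limit of the assay: the limit of > 1 h in this assay, at which 1 of the 3 values shown sits.

On these data alone, whether the kind of substituent or its place on the phenyl ring sets these steps stays open. A plain phenyl group on the same nitrogen would give all three compounds a common reference.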